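The compounds below may be only part of what the source reports. "The series", "measured", "known", "first", "only" and "open" are said of these compounds alone.

Measured so far:
- compound 1 `O=C(Oc1ccccc1)c1cc2cc(CCl)ccc2oc1=O` gives, in an assay on isolated protein for inhibition of coagulation factor XII (Homo sapiens) (on this read-out lower numbers stand for stronger inhibition and higher numbers for weaker inhibition), only a limit, > 50000 nM
- compound 2 `O=C(Nc1ccccc1)c1cc2ccccc2oc1=O` gives 42000 nM
- compound 3 `Cc1ccc2oc(=O)c(C(=O)Nc3cnc4ccccc4c3)cc2c1` gives 8300 nM

Compound 1 sits at the limit of this assay, (the limit of > 50000 nM in this assay, at which 1 of the 3 values shown sits), so no number is known for it. Among the two numbers that are known, compound 2 stands highest; compound 3 gives a lower number, and the gap between them is beyond the usual scatter of such measurements.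

Compound 4 `O=C(Nc1ccccc1)c1cc2cc([N+](=O)[O-])ccc2oc1=O` has not yet been measured. It differs from compound 2 in one place: nitro in place of hydrogen on an aromatic carbon. Within the data shown here, no pair of measured compounds shows this same change, so nothing measured tells how large the step will be or which way it will go. A modest step toward a lower number in this assay is expected from compound 2 to compound 4, of a size that may or may not clear the scatter. Compound 4 is therefore expected to give about 25000 nM in this assay, with the estimate ranging from 6000 nM to 60000 nM. That estimate is expected to amount to a step of a 1.7-fold lower number from compound 2 to compound 4 (0.23 log units; within the scatter).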

Compound 4, half-maximal inhibitory concentration: 22000 nM
Beside the measured number, compound 4's estimate is 1.1-fold (0.06 log units) above it; the range from low to high includes it.
By their numbers in this assay, from the lowest: compound 3; then compounds 4 and 2 (each within the scatter of the next). At a limit, above all of these: compound 1.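

In this assay, putting nitro in place of hydrogen on an aromatic carbon of the shared core gives a 1.9-fold lower number from compound 2 to compound 4 (0.28 log units; within the scatter). This position, on the six-membered aromatic ring of carbon only, therefore accepts a group of three heavy atoms with no change that clears the scatter, so this single pair shows no real gain or loss from the substitution. Nothing measured here accounts for the size of this step.

Going by these compounds, whether another group at the same position, such as an amine or a carboxylic acid, would move the number beyond the scatter remains open. On these data alone, it is equally open whether nitro would give a similar step at another carbon of the same ring, or on the phenyl ring of the amide.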